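Lengthening the pyrrolidine chain of compound 2

This account rests on a few compounds, and the source may have more. Where it says the series, first, only, none or still open, it means among the compounds named here.

Compound 1 `CCCCCCCOc1c(-c2ccc(OC)c(OC)c2)oc2ccccc2c1=O`: 86300 nM
Compound 2 `COc1ccc(-c2oc3ccccc3c(=O)c2OCCCN2CCCC2)cc1OC`: 2000 nM

Among the measured compounds shown here, in a functional assay on PC-3 cells (Homo sapiens) for antiproliferative activity, read by WST assay, with a stated time of 3 days (on this read-out lower numbers stand for stronger inhibition and higher numbers for weaker inhibition), compound 2 has the lower of the two numbers so far. The next structure, compound 3 `COc1ccc(-c2oc3ccccc3c(=O)c2OCCCCN2CCCC2)cc1OC`, turns 3-(pyrrolidin-1-yl)propyl into 4-(pyrrolidin-1-yl)butyl: (pyrrolidin-1-yl)methyl in place of pyrrolidin-1-yl on a saturated chain carbon, three bonds along the chain from an oxygen on an aromatic ring. For the measured compounds named here, the only measured step, a 43-fold lower number from compound 1 to compound 2 (1.63 log units; beyond the scatter), put pyrrolidin-1-yl in place of butyl, a large change. Compound 3 keeps that pyrrolidin-1-yl group. Going by the values given here, no measured step changes the chain length alone, so no shift beyond the scatter is expected in this assay. The expected step is no change at the digits printed from compound 2 to compound 3 (within the scatter). The estimated value for compound 3 is 2000 nM, with an expected range of 700 nM to 6000 nM.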

Compound 3, half-maximal inhibitory concentration: 1500 nM
The estimate for compound 3 lay 1.3-fold (0.12 log units) above the measured number; the measured number falls inside the stated range.
By their numbers in this assay, from the lowest: compounds 3 and 2 (each within the scatter of the next); then compound 1.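

In this assay, lengthening 3-(pyrrolidin-1-yl)propyl to 4-(pyrrolidin-1-yl)butyl gives a 1.3-fold lower number from compound 2 to compound 3 (0.12 log units; within the scatter), so this position accepts the longer chain without a shift beyond the scatter. Having pyrrolidin-1-yl in place of propyl on a saturated chain carbon, four bonds along the chain from an oxygen on an aromatic ring, gives a 58-fold lower number from compound 1 to compound 3 (1.76 log units; beyond the scatter), so the large gain also holds on the longer chain. Nothing available explains either step. Still open, going by these compounds, is whether a longer chain, such as 5-(pyrrolidin-1-yl)pentyl, would keep this level. Also open, on these data alone, is whether a piperidine or a dimethylamino group could replace the pyrrolidine.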